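The Same Swap, Made a Second Time

The source may hold more compounds than are shown below. What is called first, only, known or untested is meant among the compounds shown, and "the series" means these compounds.

Compound 1 `CSc1nnc(-c2ccccc2F)n1C`: 8.8 mg/kg
Compound 2 `Cn1c(-c2ccccc2F)nnc1[S+](C)[O-]`: 20 mg/kg
Compound 3 `CSc1nc(-c2ccccc2)nn1C`: > 200 mg/kg

In a functional assay on the whole organism for antagonist activity, with Mus musculus as the target (a higher number here means that more compound is needed for the effect, a lower number that less compound is needed), compound 1 gives 8.8 mg/kg. Compound 2 differs from it by a group of 3 heavy atoms (1 carbon, 1 oxygen, 1 sulfur; no ring) in place of a group of 2 heavy atoms (1 carbon, 1 sulfur; no ring), on an aromatic carbon, and that step gave a 2.3-fold higher number from compound 1 to compound 2 (0.36 log units; beyond the scatter). For compound 3 the assay reports only a limit, > 200 mg/kg. How the cores of compound 1 and compound 3 differ is not broken down here. Compound 4 `Cn1nc(-c2ccccc2)nc1[S+](C)[O-]` is not yet measured; it differs from compound 3 by a group of 3 heavy atoms (1 carbon, 1 oxygen, 1 sulfur; no ring) in place of a group of 2 heavy atoms (1 carbon, 1 sulfur; no ring), on an aromatic carbon. This is the same kind of change as before, made on the core of compound 3 rather than on that of compound 1. Because compound 3 already sits at the limit of > 200 mg/kg in this assay, at which 1 of the 3 values shown sits, and the earlier step of a 2.3-fold higher number from compound 1 to compound 2 (0.36 log units; beyond the scatter) raised the number, another limit is expected. The expected step is a step that the limit leaves unreadable from compound 3 to compound 4. Compound 4 is estimated at 450 mg/kg, between 150 mg/kg and 1500 mg/kg.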

Compound 4, dose for half-maximal effect: > 200 mg/kg
Compound 4: no number, only a limit; the forecaster's own chance of this, stated with the estimate: 85%; the middle value does not contradict the limit.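

No step can be read from compound 3 to compound 4, because both give only a limit and no number: the limit of > 200 mg/kg in this assay, at which 2 of the 4 values shown sit.

The compounds shown leave open whether this swap shifts the number on the core of compound 3 as it did on the core of compound 1.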